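The source may report more compounds than this note shows. Statements on the series, on what has been measured and on what is new or still open speak of the compounds shown alone.

For the measured compounds named here, in an assay on isolated protein for binding affinity to corticotropin-releasing factor receptor 1 (Homo sapiens) (on this read-out higher numbers stand for weaker inhibition and lower numbers for stronger inhibition), three compounds have a number so far. Compound 1 `CCCN(CC1CC1)c1nc(C)nc(N(CC)c2ccc(N(C)C)cc2C(F)(F)F)n1` gives 5 nM, the lowest of the three. Compound 2 `CCN(c1nc(C)cc(C)n1)c1c(Br)cc(C(C)C)cc1OC` gives 26 nM, and compound 3 `CCN(c1nc(C)cc(C)n1)c1ccc(C(C)C)cc1SC` gives 36 nM; both stand above compound 1 by more than the scatter, compound 3 the furthest away.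

Compound 4 `CCN(CC)c1nc(C)nc(N(CC)c2ccc(N(C)C)cc2C(F)(F)F)n1` has not yet been measured in this assay. It differs from compound 1 in one place: diethylamino in place of (cyclopropylmethyl)(propyl)amino on an aromatic carbon. Going by the values given here, no measured pair shows this exchange, so the data give no size for it. The shared core and the remaining substituents are kept, so the expected step is small, a 1.6-fold higher number from compound 1 to compound 4 (0.20 log units; within the scatter), leaning toward a slightly higher number. Compound 4 is therefore estimated at 8 nM, with a range from 3 nM to 25 nM.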

Compound 4, inhibition constant: 20 nM
Compound 4: the middle estimate sits 2.5-fold (0.40 log units) below what was measured; measured number inside the range.
By their numbers in this assay, from the lowest: compound 1; then compounds 4, 2 and 3 (each within the scatter of the next).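

At this position, on an aromatic carbon between two ring nitrogen atoms, diethylamino in place of (cyclopropylmethyl)(propyl)amino gives in this assay a 4.0-fold higher number from compound 1 to compound 4 (0.60 log units; beyond the scatter). The read-out therefore responds to the amino group here, and the larger group bearing the three-membered ring gives the lower number of the two. Nothing at hand accounts for this step. The exchange alters both chains on the nitrogen at once, so the shares of the propyl chain and the cyclopropylmethyl group stay apart from view. The compounds shown leave open where a dipropylamino group or a morpholine would stand.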